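The source may report more compounds than this note shows. Statements on the series, on what has been measured and on what is new or still open speak of the compounds shown alone.

Of the compounds shown here, three sharing one core have been read in an ADME assay on GM00637 cells (Homo sapiens) for cytotoxicity, read by MTT assay, with a stated time of 72 h (on this read-out lower numbers stand for stronger inhibition and higher numbers for weaker inhibition), and they differ only in the group on one aromatic carbon. Compound 1 (`CCNc1cc2nc(-c3ccccc3)nn(-c3ccccc3)c-2cc1=O`), with ethylamino, gives 240 nM. Compound 2 (`CCN(CC)c1cc2nc(-c3ccccc3)nn(-c3ccccc3)c-2cc1=O`), with diethylamino, gives 2730 nM, and that is an 11-fold higher number from compound 1 to compound 2 (1.06 log units; beyond the scatter). Compound 3 (`CC(=O)Nc1cc2nc(-c3ccccc3)nn(-c3ccccc3)c-2cc1=O`), with acetamido, gives > 5000 nM, which is a limit of the assay and not a number. Compound 3 thus stands at the limit of > 5000 nM in this assay, at which 1 of the 3 values shown sits, with an at least 20-fold higher number from compound 1 to compound 3 (1.31 log units; beyond the scatter) and an at least 1.8-fold higher number from compound 2 to compound 3 (0.26 log units; that floor lies within the scatter) as its measured steps.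

The change now in question leads to compound 4 (`COc1cc2nc(-c3ccccc3)nn(-c3ccccc3)c-2cc1=O`), which carries methoxy in place of acetamido on an aromatic carbon. For the measured compounds named here, no measured compound carries methoxy, so the evidence is indirect. The closest guide is an at least 20-fold higher number from compound 1 to compound 3 (1.31 log units; beyond the scatter), which shows that in this assay the number can move far with the group on this carbon, and an 11-fold higher number from compound 1 to compound 2 (1.06 log units; beyond the scatter) shows the same among the two amines. A step towards a lower number is therefore expected, larger than the scatter but smaller than the widest step seen. The expected change is an at least 4.1-fold lower number from compound 3 to compound 4 (0.61 log units; beyond the scatter). For compound 4 the estimated value is 1200 nM, with an expected range of 200 nM to 5000 nM.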

Compound 4, half-maximal inhibitory concentration: > 5000 nM
Compound 4 ended at the assay's limit (the forecaster's own chance of this, stated with the estimate: 15%); at least 4.1-fold (0.61 log units) between middle value and limit.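

In this assay, methoxy in place of ethylamino gives an at least 20-fold higher number from compound 1 to compound 4 (1.31 log units; beyond the scatter), so a second group without a nitrogen on this carbon's substituent chain joins acetamido in losing the reading of compound 1, this time with fewer heavy atoms than acetamido and no hydrogen-bond donor. Against the diethylamino group the result is an at least 1.8-fold higher number from compound 2 to compound 4 (0.26 log units; that floor lies within the scatter), so compound 4 cannot be placed apart from compound 2 on this evidence, and compound 1 remains the only one of the four with a step beyond the scatter to each compound at the limit. The step between compound 3 and compound 4 cannot be read, since each reading is a limit of the assay and not a number: the limit of > 5000 nM in this assay, at which 2 of the 4 values shown sit.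

The compounds shown leave open how far above the limit compound 3 and compound 4 lie, and so whether methoxy and acetamido truly differ here. They also leave open whether the low number of compound 1 depends on the ethyl chain or on the nitrogen with its hydrogen, which an unsubstituted amine, methylamino, propylamino or ethoxy on this same carbon would help to separate.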